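A few compounds are considered here, and "the series" means these few. Any claim that something is new, unique, unknown or untested is made for them only; others in the source may bear on it.

In an ADME assay on Vero cells (Chlorocebus sabaeus) for cytotoxicity, read by MTT assay, with a stated time of 72 h (on this read-out lower numbers stand for higher toxicity in this test and higher numbers for lower toxicity in this test), compound 1 (`N/C(=N/NC(CC(=O)c1ccc(-n2ccnc2)cc1)c1ccccc1[N+](=O)[O-])c1ccccn1`) gives 48000 nM and compound 2 (`N/C(=N/NC(CC(=O)c1ccc(-n2ccnc2)cc1)c1ccc(Cl)cc1Cl)c1ccccn1`) gives 27800 nM, so the two stand within the scatter of each other. Compound 3 (`N/C(=N/NC(CC(=O)c1ccc(-n2ccnc2)cc1)c1ccccc1Br)c1ccccn1`) has 2-bromophenyl in place of 2,4-dichlorophenyl on a saturated chain carbon bound to an amine nitrogen and a saturated chain carbon. Within the data shown here, the only measured step at that place is a 1.7-fold lower number from compound 1 to compound 2 (0.24 log units; within the scatter), and it stays within the scatter. In this assay the expected step is therefore a 1.2-fold higher number from compound 2 to compound 3 (0.09 log units; within the scatter), with no size beyond the scatter and no firm direction. For compound 3 the estimated value is 34000 nM, with an expected range of 17000 nM to 68000 nM.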

Compound 3, half-maximal cytotoxic concentration: 29000 nM
Compound 3: the middle estimate sits 1.2-fold (0.07 log units) above what was measured; the measured number falls inside the stated range.
By their numbers in this assay, from the lowest: compounds 2, 3 and 1 (each within the scatter of the next).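

In this assay the third aryl group at this place, on a saturated chain carbon bound to an amine nitrogen and a saturated chain carbon, again leaves the read-out within the scatter: the change to 2-bromophenyl gives a 1.0-fold higher number from compound 2 to compound 3 (0.02 log units; within the scatter) and bromo in place of nitro on an aromatic carbon gives a 1.7-fold lower number from compound 1 to compound 3 (0.22 log units; within the scatter). The 2-nitrophenyl, 2,4-dichlorophenyl and 2-bromophenyl compounds therefore cannot be told apart in this test. Nothing available explains this result. As far as these compounds go, whether a phenyl carrying an amine or a carboxylic acid would stay within the same scatter remains open.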